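This account rests on a few compounds, and the source may have more. Where it says the series, first, only, none or still open, it means among the compounds named here.

Of the three measured compounds, compound 1 `COC(=O)C[C@@H]1C[C@@H](O)[C@H](C)[C@H](c2ccccc2)N1` gives 6300 nM in a functional assay on DU-145 cells (Homo sapiens) for cytotoxicity, read by MTT assay; a lower number here means a stronger inhibitor, a higher number a weaker inhibitor; compound 2 `COC(=O)C[C@H]1C[C@@H](O)[C@@H](C)[C@@H](c2ccc(C(C)C)cc2)N1` gives 110000 nM, and compound 3 `COC(=O)C[C@H]1C[C@H](O)[C@@H](C)[C@@H](c2ccc(C(C)C)cc2)N1` gives 27400 nM, the second highest number of the three. Within the data shown here, the only single-point step among them, a 4.0-fold lower number from compound 2 to compound 3 (0.60 log units; beyond the scatter), rests on the fact that compounds 2 and 3 differ only in the configuration as drawn and concerns configuration, not the aromatic substituent. Compound 4 `COC(=O)C[C@H]1C[C@H](O)[C@@H](C)[C@@H](c2ccc(F)cc2)N1` differs from compound 3 by fluoro in place of isopropyl on an aromatic carbon. Among the measured compounds shown here, no measured step covers a change on the aromatic ring; compound 1, with an unsubstituted phenyl but a different configuration, sits at a lower number than compound 3, and that is all the two values show. Given compound 1 at 6300 nM, compound 4 is expected to give a modestly lower number, a step of a 2.3-fold lower number from compound 3 to compound 4 (0.36 log units; beyond the scatter), estimated at 12000 nM, between 4000 nM and 40000 nM.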

Compound 4, half-maximal inhibitory concentration: "not active" (no number reported)
Nothing numeric was reported for compound 4; no gap can be computed for the estimate.
By their numbers in this assay, from the lowest: compound 1; then compound 3; then compound 2.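

Among these compounds, compound 4 is reported as not active, with no number, and no step from compound 3 to compound 4 can be read. Open: how far fluoro in place of isopropyl shifts the number in this assay; nothing shown bears on this result.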